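The compounds below may be only part of what the source reports. "The series", "measured", "known", "first", "only" and "open" are said of these compounds alone.

In a functional assay on CWR22R cells (Homo sapiens) for antiproliferative activity, read by CCK-8 assay, with a stated time of 6 days (a lower number here means a stronger inhibitor, a higher number a weaker inhibitor), the measured compounds read as follows.

Compound 1 `C[C@@H](Cn1ccc(-c2ccc(C#N)c(Cl)c2)n1)NC(=O)C1CC(=O)C1` stands as "not determined" (no result reported) with no result reported.
Compound 2 `C[C@@H](Cn1ccc(-c2ccc(C#N)c(Cl)c2)n1)Nc1ccccc1` gives > 30000 nM as a limit of the assay.
Compound 3 `C[C@@H](Cn1ccc(-c2ccc(C#N)c(Cl)c2)n1)Nc1cncnc1` gives > 30000 nM as a limit of the assay.

Compound 3 therefore has no number of its own in this assay and stands only at a limit, as compound 2 does. Within the data shown here, the one measured step is a step that the two limits leave unreadable from compound 2 to compound 3 and it offers no size to carry forward. Among the measured compounds shown here, the only other evidence is the limit of > 30000 nM in this assay, at which 2 of the 3 values shown sit, and it shows where the series sits, not how far a new group might move it.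

Compound 4 `C[C@@H](Cn1ccc(-c2ccc(C#N)c(Cl)c2)n1)Nc1ncnc2nc[nH]c12` differs from compound 3 by one change: a group of 9 heavy atoms (5 carbon, 4 nitrogen; one five-membered aromatic ring with 2 hetero atoms, one six-membered aromatic ring with 2 hetero atoms) in place of a group of 6 heavy atoms (4 carbon, 2 nitrogen; one six-membered aromatic ring with 2 hetero atoms), on an amine nitrogen. For the measured compounds named here, the larger group adds a five-membered aromatic ring to the six-membered one, but no measured step tests such a change. The expectation rests on compound 3, whose reading of > 30000 nM is a limit. A modest gain in this assay is possible, though no direction is established and compound 4 is expected to stay close to that limit.

The expected step is an at least 1.2-fold lower number from compound 3 to compound 4 (0.07 log units; that floor lies within the scatter) and this estimate remains loose. For compound 4 the estimated value is 25000 nM with an expected range from 5000 nM to 60000 nM and a report of only a limit is quite likely.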

Compound 4, half-maximal inhibitory concentration: 4240 nM
For compound 4 the middle estimate is 5.9-fold (0.77 log units) above the measured one; the whole stated range lies above it.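

Until compound 4, the substituents shown on the amine nitrogen gave no number in this assay, only a limit: the limit of > 30000 nM in this assay, at which 2 of the 4 values shown sit.

Putting the group of 9 heavy atoms, with its five-membered aromatic ring alongside the six-membered one, in place of pyrimidin-5-yl gives an at least 7.0-fold lower number from compound 3 to compound 4 (0.84 log units; beyond the scatter), and putting it in place of phenyl gives an at least 7.0-fold lower number from compound 2 to compound 4 (0.84 log units; beyond the scatter). Among these compounds, both steps are floors rather than measured sizes, yet they show for the first time that a change at this place on the amine nitrogen can bring a readable result in this assay.

The compounds shown do not separate what the added five-membered ring contributes from what its hydrogen-bond donor contributes, since the entering group differs from pyrimidin-5-yl in both at once. As far as these compounds go, a naphthyl group on the same nitrogen, or a methyl group in place of the hydrogen on the nitrogen of the five-membered ring, would bear on that question, and how far the reading can fall at this place remains open.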